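The compounds below may be only part of what the source reports. "The series", "measured", "known", "first", "only" and "open" are said of these compounds alone.

In a physicochemical assay for lipophilicity, measured as octanol-water partition, at pH 7.4 (a lower number here means a more polar compound, a higher number a more lipophilic compound), compound 1 (`Cc1ccc2[nH]c(C(=O)N[C@H]3CN(S(=O)(=O)c4ccnnc4)C[C@@H]3C(=O)NCCN(C)C)cc2c1`) gives 0.7 and compound 2 (`Cc1ccc2[nH]c(C(=O)N[C@H]3CN(S(=O)(=O)c4ccccc4)C[C@@H]3C(=O)NC[C@H]3CCCN3)cc2c1`) gives 1. Within the data shown here, these two values lie within the usual scatter of repeated measurements, so they set no order between the compounds. The two structures also differ in more than one place, so the pair says little about any single group.

Compound 3 (`Cc1ccc2[nH]c(C(=O)N[C@H]3CN(S(=O)(=O)c4ccccc4)C[C@@H]3C(=O)NC[C@H]3CCCN3C)cc2c1`) differs from compound 2 in one place only: methyl in place of hydrogen on an amine nitrogen in a ring. This is methyl in place of hydrogen on an amine nitrogen in a ring, turning pyrrolidin-2-yl into 1-methylpyrrolidin-2-yl. Among the measured compounds shown here, no measured pair here shows this change, so the expectation rests on the structural change alone.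

A small rise in this assay is expected, only slightly beyond the scatter. The estimated size is a number 0.40 log units higher from compound 2 to compound 3 (beyond the scatter). For compound 3 the estimated value is 1.4, with an expected range from 1 to 1.9.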

Compound 3, distribution coefficient: 2.3
Beside the measured number, compound 3's estimate is 0.90 log units below it, and the stated range ends below it.
By their numbers in this assay, from the lowest: compounds 1 and 2 (each within the scatter of the next); then compound 3.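

Among these compounds, this is the first comparison that changes only one place: in this assay, methyl in place of hydrogen on an amine nitrogen in a ring gives a number 1.30 log units higher from compound 2 to compound 3 (beyond the scatter) and counts as a large step. It shows that this nitrogen, in a five-membered non-aromatic ring with 1 nitrogen, is a position where one added carbon moves the reading well beyond the scatter, something compound 1 and compound 2, which differ in more than one place, could not show. The data shown offer no measurement that explains the size of this step.

As far as these compounds go, whether a longer chain on this nitrogen, such as ethyl, or an acetyl group would move the number further remains open. So does whether the same methyl would give a step of this size on a piperidine in place of the pyrrolidine.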